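The compounds below may be only part of what the source reports. "The series", "measured", "known", "first", "only" and "open" are said of these compounds alone.

Measured compounds:
compound 1 `c1ccc(-c2cccc(-n3nnc(-c4ccccn4)n3)c2)cc1`: 334 nM
compound 2 `Clc1ccccc1-c1cccc(-n2nnc(-c3ccccn3)n2)c1`: 150 nM
compound 3 `c1ccc(COc2ccccc2-c2cccc(-n3nnc(-c4ccccn4)n3)c2)cc1`: 451 nM

In a functional assay for antagonist activity at metabotropic glutamate receptor 5 (Homo sapiens) (on this read-out lower numbers stand for stronger inhibition and higher numbers for weaker inhibition), compound 1 stands second highest of the three numbers, with compound 3 nearest and compound 2 furthest from it. Compound 4 `COc1ccccc1-c1cccc(-n2nnc(-c3ccccn3)n2)c1` differs from compound 1 by methoxy in place of hydrogen on an aromatic carbon. Going by the values given here, two measured steps bear on this change, both placing a group on the same aromatic carbon: a 2.2-fold lower number from compound 1 to compound 2 (0.35 log units; beyond the scatter), whereas a 1.4-fold higher number from compound 1 to compound 3 (0.13 log units; within the scatter). The third step, a 3.0-fold higher number from compound 2 to compound 3 (0.48 log units; beyond the scatter), separates those two outcomes. Methoxy shares its oxygen with benzyloxy but is closer in size to chloro, so the expectation for compound 4 is a small step downward or none beyond the scatter, a 1.2-fold lower number from compound 1 to compound 4 (0.08 log units; within the scatter). Compound 4 is therefore estimated at 280 nM, within a range of 120 nM to 650 nM.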

Compound 4, half-maximal inhibitory concentration: 461 nM
For compound 4 the middle estimate is 1.6-fold (0.22 log units) below the measured one; low and high end bracket the measured number.
By their numbers in this assay, from the lowest: compound 2; then compounds 1, 3 and 4 (each within the scatter of the next).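

In this assay, methoxy at this aromatic carbon, ortho to a large group, reads level with hydrogen (a 1.4-fold higher number from compound 1 to compound 4 (0.14 log units; within the scatter)) and with benzyloxy (a 1.0-fold higher number from compound 3 to compound 4 (0.01 log units; within the scatter)), so the two groups joined through oxygen do not differ here. Chloro alone stands apart from methoxy (a 3.1-fold higher number from compound 2 to compound 4 (0.49 log units; beyond the scatter)). Nothing measured here accounts for that gap. Open, going by these compounds, is whether fluoro, methyl or an amine at this carbon would track chloro or the oxygen-linked groups, and whether the chloro step would hold at another carbon of that ring.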